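Working notes: 4-methoxyphenyl replacement in compound 2

This account rests on a few compounds, and the source may have more. Where it says the series, first, only, none or still open, it means among the compounds named here.

Values in a functional assay on HepG2 cells (Homo sapiens) for antiproliferative activity, read by MTT assay, with a stated time of 48 h; a lower number here means a stronger inhibitor, a higher number a weaker inhibitor:
- compound 1 `COc1ccc(-c2c(Nc3cc(OC)c(OC)c(OC)c3)c3ccccc3oc2=O)cc1`: 77300 nM
- compound 2 `COc1ccc(-c2c(Nc3cc(OC)c(OC)c(OC)c3)c3ccc(OC)cc3oc2=O)cc1`: 84300 nM
- compound 3 `COc1ccc(-c2c(Nc3cc(OC)c(OC)c(OC)c3)c3ccc(O)cc3oc2=O)cc1`: 49700 nM

Compound 2 lies within the scatter of both compound 1 and compound 3. Compound 4 `COc1ccc2c(Nc3cc(OC)c(OC)c(OC)c3)c(C(=O)C(F)(F)F)c(=O)oc2c1` is still unmeasured, and its change is (trifluoromethyl)carbonyl in place of 4-methoxyphenyl on an aromatic carbon. Three measured steps exist: a 1.1-fold higher number from compound 1 to compound 2 (0.04 log units; within the scatter), a 1.6-fold lower number from compound 1 to compound 3 (0.19 log units; within the scatter) and a 1.7-fold lower number from compound 2 to compound 3 (0.23 log units; within the scatter). All stay within the scatter, but none touches the 4-methoxyphenyl, so the series offers no measured guide to this replacement. In this assay, a modest move towards a lower number is expected, with the direction uncertain. The expected step is a 1.9-fold lower number from compound 2 to compound 4 (0.27 log units; within the scatter). For compound 4 the estimated value is 45000 nM, with an expected range of 12000 nM to 110000 nM.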

Compound 4, half-maximal inhibitory concentration: 26400 nM
Beside the measured number, compound 4's estimate is 1.7-fold (0.23 log units) above it, within the range that was stated.
By their numbers in this assay, from the lowest: compounds 4, 3, 1 and 2 (each within the scatter of the next, the first and the last beyond it).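

For the compounds shown here, at this position the aromatic ring is not needed to hold the activity: in this assay, (trifluoromethyl)carbonyl in place of 4-methoxyphenyl gives a 3.2-fold lower number from compound 2 to compound 4 (0.50 log units; beyond the scatter), the only step beyond the scatter. Going by these compounds alone, the earlier steps touched only the other end of the core, so this is the first sign that this position can move the number. No data shown here account for the step.

The compounds shown do not separate the contribution of the carbonyl from that of the trifluoromethyl. An acetyl group or a carboxylic acid at this position would test that split.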